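Methyl in place of methoxycarbonyl on the side chain

A few compounds are considered here, and "the series" means these few. Any claim that something is new, unique, unknown or untested is made for them only; others in the source may bear on it.

In a functional assay on K562 cells (Homo sapiens) for inhibition, read by trypan blue exclusion, with a stated time of 72 h (a higher number here means a weaker inhibitor, a lower number a stronger inhibitor), compound 1 (`COC(=O)Cn1c(=O)c(S(=O)(=O)c2ccc(F)cc2F)cc2cnc(Nc3ccc4[nH]ccc4c3)nc21`) gives 5000 nM and stands level with compound 2 (`Cn1c(=O)c(C(=O)Nc2ccc(F)cc2F)cc2cnc(Nc3ccc4[nH]ccc4c3)nc21`) at 5000 nM on the same read-out. Compound 3 (`CCn1c(=O)c(S(=O)(=O)c2ccc(F)cc2F)cc2cnc(Nc3ccc4[nH]ccc4c3)nc21`) differs from compound 1 in one group (methyl in place of methoxycarbonyl on a saturated chain carbon bound to an aromatic nitrogen): methyl in place of methoxycarbonyl on a saturated chain carbon bound to an aromatic nitrogen. Among the compounds with values here, no measured pair shows this change, so only a modest move toward stronger inhibition is expected (a 2.0-fold lower number from compound 1 to compound 3 (0.30 log units; within the scatter) as estimated). In this assay compound 3 is estimated at 2500 nM with a range from 400 nM to 10000 nM expected.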

Compound 3, half-maximal inhibitory concentration: 750 nM
The estimate for compound 3 lay 3.3-fold (0.52 log units) above the measured number; the range from low to high includes it.
By their numbers in this assay, from the lowest: compound 3; then compounds 1 and 2 (each within the scatter of the next).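

In this assay methyl in place of methoxycarbonyl gives a 6.7-fold lower number from compound 1 to compound 3 (0.82 log units; beyond the scatter) and this step lies beyond the scatter, so the group on this saturated chain carbon bound to an aromatic nitrogen matters for the read-out. Compounds 1 and 2 differ in more than one place and could not show this. Nothing measured here accounts for the step.

Open, from the compounds shown here alone, is whether a longer chain, an amine or a carboxylic acid in this place would give a lower or a higher number than the ethyl of compound 3.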